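The source may hold more compounds than are shown below. What is called first, only, known or untested is meant among the compounds shown, and "the series" means these compounds.

In a functional assay on MDA-MB-231 cells (Homo sapiens) for antiproliferative activity, read by MTT assay, with a stated time of 72 h (a lower number here means a stronger inhibitor, a higher number a weaker inhibitor), compound 1 `CC1=CC[C@H]2[C@H](CC[C@]2(C)O)C(C)(C)[C@@H]1CC[C@H]1[C@]2(C)CC[C@H](OC(=O)CCC(=O)O)C(C)(C)O[C@H]2CC[C@@]1(C)O` gives 27900 nM, compound 2 `CC1=CC[C@H]2[C@@H]1CC=C(C)[C@@H](CC[C@H]1[C@]3(C)CC[C@H](OC(=O)CCC(=O)O)C(C)(C)O[C@H]3CC[C@@]1(C)O)C2(C)C` gives 29600 nM and compound 3 `CC1=CC[C@H]2[C@@H]1CC=C(C)[C@@H](CC[C@H]1[C@]3(C)CC[C@H](OC(=O)c4ccccc4)C(C)(C)O[C@H]3CC[C@@]1(C)O)C2(C)C` gives 18400 nM, so compound 3 stands within the scatter of both others. Compound 4 `CC1=CC[C@H]2[C@@H]1CC=C(C)[C@@H](CC[C@H]1[C@]3(C)CC[C@H](OC(=O)c4ccc(C)cc4)C(C)(C)O[C@H]3CC[C@@]1(C)O)C2(C)C` differs from compound 3 by methyl in place of hydrogen on an aromatic carbon, para to a large group. Within the data shown here, no measured step tests such a change. The nearest one, a 1.6-fold lower number from compound 2 to compound 3 (0.21 log units; within the scatter), puts phenyl in place of 2-carboxyethyl on a carbonyl carbon. A shift beyond the scatter is therefore not expected in this assay. The expected step is a 1.0-fold lower number from compound 3 to compound 4 (0.01 log units; within the scatter). Compound 4 is estimated at 18000 nM, with an expected range from 10000 nM to 33000 nM.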

Compound 4, half-maximal inhibitory concentration: 32700 nM
The estimate for compound 4 lay 1.8-fold (0.26 log units) below the measured number, and the stated range covers the measured number.
By their numbers in this assay, from the lowest: compounds 3, 1, 2 and 4 (each within the scatter of the next).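

In this assay, methyl in place of hydrogen on an aromatic carbon, para to a large group, gives a 1.8-fold higher number from compound 3 to compound 4 (0.25 log units; within the scatter) as the first measured test of this change, and it shows no shift beyond the scatter. With 4-methylphenyl in place of 2-carboxyethyl on a carbonyl carbon, a 1.1-fold higher number from compound 2 to compound 4 (0.04 log units; within the scatter) also shows no shift beyond the scatter. No evidence at hand explains either step. As far as these compounds go, whether a methoxy group, a chlorine atom or an amine at this position would move the number beyond the scatter remains open.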